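Cyclising the amine of compound 1 into a piperidine

The source may hold more compounds than are shown below. What is called first, only, known or untested is meant among the compounds shown, and "the series" means these compounds.

The series shares a core carrying a trifluoromethyl group and an aminomethyl arm. Compound 1 `C=CCN(CCC)Cc1c(C(F)(F)F)nc2n(-c3c(C)cc(C)cc3C)c(Cl)cn12` holds an allyl(propyl)amino on that arm and gives 4.5 nM in an assay on cells for displacement of a labelled ligand from corticotropin-releasing factor receptor 1 (Homo sapiens), with a stated time of 100 min; on this read-out higher numbers stand for weaker inhibition and lower numbers for stronger inhibition; this is the lowest of the three numbers measured, the nearest being compound 2 and the furthest compound 3. Compound 2 `CCCN(Cc1ccc(Cl)cc1)Cc1c(C(F)(F)F)nc2n(-c3c(C)cc(C)cc3C)c(Cl)cn12` gives 28 nM in this assay, and compound 3 `CCCN(Cc1ccc([N+](=O)[O-])cc1)Cc1c(C(F)(F)F)nc2n(-c3c(C)cc(C)cc3C)c(Cl)cn12` gives 150 nM. Both measured steps from compound 1 enlarge one of the two groups on the amine nitrogen: a 6.2-fold higher number from compound 1 to compound 2 (0.79 log units; beyond the scatter), and a 33-fold higher number from compound 1 to compound 3 (1.52 log units; beyond the scatter); between those two, a 5.4-fold higher number from compound 2 to compound 3 (0.73 log units; beyond the scatter).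

Compound 4 `Cc1cc(C)c(-n2c(Cl)cn3c(CN4CCCCC4)c(C(F)(F)F)nc23)c(C)c1` differs from compound 1 as follows: piperidin-1-yl in place of allyl(propyl)amino on a saturated chain carbon bound to an aromatic carbon. For the measured compounds named here, no measured step closes the amine into a ring, so the change is not covered directly. The measured steps only show that this region tolerates replacement of vinyl by 4-chlorophenyl at a modest cost and by 4-nitrophenyl at a large one. A step no larger than the modest one is therefore expected in this assay, toward a higher number: the expected step is a 2.7-fold higher number from compound 1 to compound 4 (0.43 log units; beyond the scatter). Compound 4 is estimated at 12 nM, within 4 nM to 40 nM.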

Compound 4, inhibition constant: 1200 nM
Compound 4: the middle estimate sits 100-fold (2.00 log units) below what was measured, and the stated range ends below it.
By their numbers in this assay, from the lowest: compound 1; then compound 2; then compound 3; then compound 4.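

Closing the amine into a ring costs far more than either open-chain enlargement: in this assay piperidin-1-yl in place of allyl(propyl)amino gives a 270-fold higher number from compound 1 to compound 4 (2.43 log units; beyond the scatter), which also exceeds a 33-fold higher number from compound 1 to compound 3 (1.52 log units; beyond the scatter). The position therefore does not simply penalise larger groups, since the entering group has 6 heavy atoms against 7 in the group that leaves, while the open-chain amines keep lower numbers despite their added aromatic rings: compound 2 gives 28 nM and compound 3 gives 150 nM, against 1200 nM for compound 4. Nothing available here accounts for the size of this step.

The compounds shown cannot separate the effect of ring closure itself from that of losing the allyl and propyl chains, so diethylamino or dipropylamino on the same saturated chain carbon would address a different question from pyrrolidin-1-yl or azepan-1-yl. As far as these compounds go, it also remains open whether the steep rise is specific to piperidin-1-yl or extends to other cyclic amines, such as morpholin-4-yl, at this place.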